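The compounds below may be only part of what the source reports. "The series", "measured", "known", "first", "only" and "open" are said of these compounds alone.

Compound 2, with the structure `Cc1n[nH]c(-c2nc(Cc3ccccc3F)c3ccccn23)n1`, was tested in an in vitro ADME assay on microsomes from liver (Homo sapiens) for metabolic stability; a lower number here means slower removal, a higher number faster removal of the compound. In this assay compound 2 gives 124 mL.min-1.g-1, which is the higher of the two numbers recorded so far. Within the data shown here, the only other measured compound is compound 1, with the structure `Fc1ccccc1Cc1nc(-c2nc(C(F)(F)F)n[nH]2)c2ccccn12`; in this assay compound 1 gives 20 mL.min-1.g-1, a lower number, and the gap between the two lies beyond the usual scatter of repeated measurements.

The next compound, compound 3, has the structure `CS(=O)(=O)c1n[nH]c(-c2nc(Cc3ccccc3F)c3ccccn23)n1`. It differs from compound 2 in one place: methylsulfonyl in place of methyl on an aromatic carbon of a five-membered aromatic ring with 3 nitrogen.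

Among the measured compounds shown here, no measured pair here shows what this exchange does. Because compound 2 gives 124 mL.min-1.g-1, the high end of what has been seen, a step downward is expected, of about a 3.1-fold lower number from compound 2 to compound 3 (0.49 log units; beyond the scatter). For compound 3 the estimated result in this assay is 40 mL.min-1.g-1, with a range from 12 mL.min-1.g-1 to 110 mL.min-1.g-1.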

Compound 3, intrinsic clearance in microsomes: 11 mL.min-1.g-1
Compound 3: the middle estimate sits 3.6-fold (0.56 log units) above what was measured; the whole stated range lies above it.
By their numbers in this assay, from the lowest: compounds 3 and 1 (each within the scatter of the next); then compound 2.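

Among these compounds, replacing methyl with methylsulfonyl on the aromatic carbon of the five-membered aromatic ring with 3 nitrogen gives, in this assay, an 11-fold lower number from compound 2 to compound 3 (1.05 log units; beyond the scatter), and this is the only direct reading so far of a change at this carbon. It shows that this position, between two ring nitrogen atoms, matters for the read-out: a single exchange, with the rest of the structure the same, moves the number far beyond the scatter. Nothing measured here explains the drop, so it cannot be tied to any one feature of the methylsulfonyl group.

Among the compounds shown here, only two groups can be compared directly at this carbon, so it remains open whether an amine, a nitrile or a carboxylic acid there would give a similar step. A single pair also cannot show whether the same exchange would have a similar effect on a different core.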